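A few compounds are considered here, and "the series" means these few. Any claim that something is new, unique, unknown or untested is made for them only; others in the source may bear on it.

Compound 1 `CCCCNC(=O)N1CC1C#N`: 6700 nM
Compound 2 `N#CC1CN1C(=O)NC1CCCCC1`: 8900 nM

Both compounds were tested in a functional assay on MCF7 cells (Homo sapiens) for inhibition; a higher number here means a weaker inhibitor, a lower number a stronger inhibitor. Compound 1 gives 6700 nM; compound 2 gives 8900 nM. Of the two numbers, that of compound 1 is the lower, but its gap to compound 2 lies within the scatter, so the two cannot be told apart. They differ only in what hangs on the amide-type nitrogen of the urea, and in this pair a ring and a straight chain there give much the same result.

Compound 3 `CNC(=O)N1CC1C#N` has not yet been measured in this assay. It differs from compound 1 by hydrogen in place of propyl on a saturated chain carbon bound to an amide-type nitrogen, that is, butyl to methyl. Going by the values given here, no measured pair shows a shortening of this kind, so the size of the step is uncertain. Compound 3 is expected to come out somewhat weaker, at around 15000 nM, with a likely range of 5000 nM to 50000 nM. The step from compound 1 to compound 3 is expected to be a 2.2-fold higher number from compound 1 to compound 3 (0.35 log units; beyond the scatter).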

Compound 3, half-maximal inhibitory concentration: 17000 nM
The estimate for compound 3 lay 1.1-fold (0.05 log units) below the measured number; the measured number falls inside the stated range.
By their numbers in this assay, from the lowest: compounds 1, 2 and 3 (each within the scatter of the next, the first and the last beyond it).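

Shortening butyl to methyl gives a 2.5-fold higher number from compound 1 to compound 3 (0.40 log units; beyond the scatter), the first step in this series that stands beyond the scatter, though a modest one. The earlier pair, with its ring and straight chain, could not be told apart, whereas this change shows that what sits on the amide-type nitrogen of the urea can move the number in this assay, while compound 3 still gives a measurable value with only methyl there. Nothing measured here explains why the shorter chain gives the higher number.

Ethyl and propyl are not among the compounds shown, so it remains open whether the number climbs gradually along the chain or changes at one particular length. Also open, going by these compounds, is what a longer chain such as octyl, or a chain ending in an amine or a carboxylic acid, would give.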